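The compounds below may be only part of what the source reports. "The series", "measured", "known", "first", "only" and "open" are said of these compounds alone.

Measured compounds:
compound 1 `COc1cc2ncnc(Nc3ccc(F)c(Cl)c3)c2cc1NC(=O)/C=C/c1ccc(F)cc1Cl`: "not determined" (no result reported)
compound 2 `COc1ccc(/C=C/C(=O)Nc2cc3c(Nc4ccc(F)c(Cl)c4)ncnc3cc2O[C@H]2CCOC2)c(OC)c1OC`: 4830 nM

Working notes on the series. In a functional assay on HeLa cells (Homo sapiens) for cytotoxicity, read by MTT assay, with a stated time of 72 h (on this read-out higher numbers stand for weaker inhibition and lower numbers for stronger inhibition), compound 1 has no result, so it stands nowhere on the numbers shown: the only value here belongs to compound 2, which in this assay gives 4830 nM. Among the compounds with values here, compound 2 differs from both compound 1 and compound 3 in more than one place, so no single step can be drawn from it.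

Compound 3 `O=C(/C=C/c1ccc(F)cc1Cl)Nc1cc2c(Nc3ccc(F)c(Cl)c3)ncnc2cc1O[C@H]1CCOC1` is not yet measured. It differs from compound 1 by oxolan-3-yl in place of methyl on an oxygen on an aromatic ring. Within the data shown here, with compound 1 unmeasured, no step between measured compounds exists for this change; the same change is carried by compound 2 without a matching partner, so the size of the step remains unknown. For this assay compound 3 is expected to land somewhere in the range spanned by compound 2 at 4830 nM.

Compound 3 is estimated at 3500 nM, with a range from 700 nM to 15000 nM.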

Compound 3, half-maximal inhibitory concentration: 37500 nM
Beside the measured number, compound 3's estimate is 11-fold (1.03 log units) below it, outside the stated range (above it).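

In this assay, within the data shown here, with the (oxolan-3-yl)oxy group held constant, 2-chloro-4-fluorophenyl in place of 2,3,4-trimethoxyphenyl gives a 7.8-fold higher number from compound 2 to compound 3 (0.89 log units; beyond the scatter), the first readable step and a move towards weaker inhibition. Among these compounds, this shows that the aromatic group on the double-bonded chain carbon affects the read-out on this core, although only this one pair supports that reading. The change from methoxy to (oxolan-3-yl)oxy cannot be read because compound 1 has no result, and nothing at hand explains the size of the step from the aromatic group.

The compounds shown leave open whether the step would hold with methoxy on the aromatic ring oxygen. They also leave open how a phenyl carrying a dimethylamino group or a carboxylic acid would fall at the same chain carbon.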